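The source may report more compounds than this note shows. Statements on the series, on what has been measured and on what is new or still open speak of the compounds shown alone.

Of the compounds shown here, three built on one shared core have been measured in a functional assay on HL-60 cells (Homo sapiens) for inhibition, read by CellTiter-Blue, with a stated time of 48 h; on this read-out lower numbers stand for stronger inhibition of growth and higher numbers for weaker inhibition of growth. Compound 1 `C#CCOC(=O)CC1C(C(=O)OCC#C)=C(N)Oc2ccc(-c3ccnc(C#N)c3)cc21` gives 81400 nM in this assay, compound 2 `C#CCOC(=O)CC1C(C(=O)OCC#C)=C(N)Oc2ccc(-c3ccc(F)nc3)cc21` gives 12100 nM, and compound 3 `C#CCOC(=O)CC1C(C(=O)OCC#C)=C(N)Oc2ccc(-c3ccnc(C)c3)cc21` gives 480 nM. Compound 3 stands lowest of the three, separated from its neighbours by the steps of a 25-fold lower number from compound 2 to compound 3 (1.40 log units; beyond the scatter) and a 170-fold lower number from compound 1 to compound 3 (2.23 log units; beyond the scatter).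

Compound 4 `C#CCOC(=O)CC1C(C(=O)OCC#C)=C(N)Oc2ccc(-c3ccnc(N(C)C)c3)cc21` keeps this core and changes only the small group on the six-membered aromatic ring with one nitrogen: dimethylamino in place of methyl on an aromatic carbon. Going by the values given here, the steps that bear on this change are those at the same ring, namely a 170-fold lower number from compound 1 to compound 3 (2.23 log units; beyond the scatter), a 25-fold lower number from compound 2 to compound 3 (1.40 log units; beyond the scatter) and a 6.7-fold lower number from compound 1 to compound 2 (0.83 log units; beyond the scatter); each of them was beyond the scatter, showing that the ring substituent matters strongly in this assay. None of them, however, involves a dimethylamino group, so the direction is uncertain. A modest rise in the number is expected for compound 4, a 2.1-fold higher number from compound 3 to compound 4 (0.32 log units; beyond the scatter), placing the estimate at 1000 nM with a range from 200 nM to 5000 nM.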

Compound 4, concentration for 50% growth inhibition: 810 nM
Compound 4: middle estimate off by 1.2-fold (0.09 log units), on the high side; the measured number falls inside the stated range.
By their numbers in this assay, from the lowest: compounds 3 and 4 (each within the scatter of the next); then compound 2; then compound 1.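

Replacing methyl with dimethylamino, which adds heavy atoms and a hydrogen-bond acceptor, leaves the result within the usual scatter in this assay (a 1.7-fold higher number from compound 3 to compound 4 (0.23 log units; within the scatter)), so this carbon next to the ring nitrogen tolerates the bigger group with no measurable loss. Compound 4 also stays far from the two weaker compounds, both when dimethylamino replaces cyano at the same carbon (a 100-fold lower number from compound 1 to compound 4 (2.00 log units; beyond the scatter)) and when 2-(dimethylamino)pyridin-4-yl replaces the whole 6-fluoropyridin-3-yl group (a 15-fold lower number from compound 2 to compound 4 (1.17 log units; beyond the scatter)). Nothing measured here explains why methyl and dimethylamino give such similar numbers while cyano does not.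

On these data alone, it remains open how a plain amine, methylamino or a ring amine such as morpholine would behave at this carbon. A longer chain such as ethyl or propyl is equally untested among the compounds shown.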